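The source may hold more compounds than are shown below. What is called first, only, known or untested is meant among the compounds shown, and "the series" means these compounds.

Compound 1 `CC[C@H](C)[C@H](NC(=O)CN(c1nc(Cl)nc2[nH]cnc12)C1CC1)C(=O)O` gives 27.4% in a functional assay on the whole organism (Tail, strain ICR) with Mus musculus as the target, in the tail flick test, with a stated time of 90 min, at a dose of 25 umol/kg by the oral route; a higher number here means a stronger effect of the compound at the dose given, a lower number a weaker effect.
Compound 2 `NCCCC[C@H](NC(=O)CN(c1nc(Cl)nc2[nH]cnc12)C1CC1)C(=O)O` gives 28.8% in this assay.
Compound 3 `CC(C)[C@H](NC(=O)CN(c1nc(Cl)nc2[nH]cnc12)C1CC1)C(=O)O` gives 30.3% in this assay.

Compound 3 carries the highest of the three numbers, yet its gaps to the others are small: a number 1.5 percentage points higher from compound 2 to compound 3 (within the scatter) and a number 2.9 percentage points higher from compound 1 to compound 3 (within the scatter), so the three compounds cannot be told apart by this measurement.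

Compound 4 `O=C(O)C[C@H](NC(=O)CN(c1nc(Cl)nc2[nH]cnc12)C1CC1)C(=O)O` differs from compound 3 in the side chain: carboxymethyl in place of isopropyl on a saturated chain carbon bound to an amide-type nitrogen and a carbonyl carbon.

Two measured steps exchange the group on that same carbon, and both stayed within the scatter: a number 1.4 percentage points higher from compound 1 to compound 2 (within the scatter) and a number 1.5 percentage points higher from compound 2 to compound 3 (within the scatter). For the measured compounds named here, none of the measured compounds carries a carboxymethyl group there, so this particular group is untested. Going by the values given here, since every change at this position so far left the number about where it was, the step to compound 4 is expected to be of the same kind, a number 2.3 percentage points lower from compound 3 to compound 4 (within the scatter), with no movement beyond the scatter in either direction.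

Compound 4 is therefore estimated at 28% in this assay, with a range from 15% to 41%.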

Compound 4, a percentage reported as activity, at one dose (the size of the read-out at that dose, not a potency): 25.1%
Estimate against measurement, compound 4: 2.9 percentage points above; low and high end bracket the measured number.
By their numbers in this assay, from the lowest: compounds 4, 1, 2 and 3 (each within the scatter of the next).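

Carboxymethyl brings oxygen atoms, a hydrogen-bond donor and a hydrogen-bond acceptor that isopropyl lacks, yet this assay still does not separate the compounds: a number 5.2 percentage points lower from compound 3 to compound 4 (within the scatter), a number 3.7 percentage points lower from compound 2 to compound 4 (within the scatter) and a number 2.3 percentage points lower from compound 1 to compound 4 (within the scatter). The saturated chain carbon bound to an amide-type nitrogen and a carbonyl carbon has therefore now carried four different groups, including one with an amine and one with a carboxylic acid, and none stands apart from the others at this dose. No measurement is available that could explain this lack of separation.

On these data alone, it remains open whether a benzyl group, an aromatic ring of another kind or a plain hydrogen on this carbon would give a step beyond the scatter. As far as these compounds go, all four compounds were compared at a single dose, and whether any of them would give a stronger or weaker effect than the others at another dose remains unknown.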